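The compounds below may be only part of what the source reports. "The series", "measured", "known", "first", "only" and "open" are said of these compounds alone.

Measured in a functional assay on HCT-116 cells (Homo sapiens) for inhibition, read by sulforhodamine B assay, with a stated time of 48 h, tested at 50 uM; a higher number here means more inhibition of growth at the concentration tested, a lower number less inhibition of growth:
- compound 1 `COc1ccc(/C=C/C(=O)/C=C/c2ccc(OCc3cn(CCCCOc4cc(=O)oc5ccccc45)nn3)c(OC)c2)cc1OC`: 55%
- compound 2 `COc1cc(/C=C/C(=O)/C=C/c2ccccc2)ccc1OCc1cn(CCCCOc2cc(=O)oc3ccccc23)nn1`: 34%

Of these two, compound 2 stands lower, at 34%, and its gap to compound 1 lies beyond the scatter. Compound 3 `COc1cc(/C=C/C(=O)/C=C/c2cccc3ccccc23)ccc1OCc1cn(CCCCOc2cc(=O)oc3ccccc23)nn1` keeps the core of compound 2 and makes one change: naphthalen-1-yl in place of phenyl on a double-bonded chain carbon bound to a double-bonded chain carbon. Naphthalen-1-yl takes the place of phenyl on a double-bonded chain carbon bound to a double-bonded chain carbon. Among the compounds with values here, one measured step touches this same place: a number 21 percentage points lower from compound 1 to compound 2 (beyond the scatter). Phenyl there went with the lower number, so a modest rise in this assay is expected, though no compound carrying naphthalen-1-yl has been measured and the direction remains uncertain. The expected change is a number 8 percentage points higher from compound 2 to compound 3 (within the scatter). For compound 3 the estimated value is 42%, with an expected range of 25% to 60%.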

Compound 3, percent growth inhibition at one concentration: 56%
For compound 3 the middle estimate is 14 percentage points below the measured one, and the stated range covers the measured number.
By their numbers in this assay, from the lowest: compound 2; then compounds 1 and 3 (each within the scatter of the next).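

In this assay, naphthalen-1-yl in place of phenyl on a double-bonded chain carbon bound to a double-bonded chain carbon gives a number 22 percentage points higher from compound 2 to compound 3 (beyond the scatter), so a second route away from phenyl now exists at this position, one that adds only aromatic carbon. Set against 3,4-dimethoxyphenyl at the same place, naphthalen-1-yl gives a number 1 percentage points higher from compound 1 to compound 3 (within the scatter), which leaves the two groups indistinguishable in this assay and phenyl as the only one of the three standing apart. Nothing available explains this result.

The compounds shown leave open whether naphthalen-2-yl, or a phenyl ring carrying a single methoxy group, would fall with compound 1 and compound 3 or with compound 2. They also do not tell how a phenyl ring bearing an amine would behave at this place.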